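A few compounds are considered here, and "the series" means these few. Any claim that something is new, unique, unknown or untested is made for them only; others in the source may bear on it.

Measured so far:
compound 1, `CCCNC(=O)/N=C(\N)NCCCc1sc(N)nc1C`: 170 nM
compound 2, `Cc1nc(N)sc1CCCN/C(N)=N/C(=O)NCc1ccccc1`: 100 nM

Both values come from a functional assay on HEK293T cells for agonist activity at histamine H2 receptor (Homo sapiens), read by beta-arrestin recruitment; on this read-out higher numbers stand for an effect only at larger amounts of compound and lower numbers for an effect already at smaller amounts. Compound 2 carries the lowest of the two numbers, and its nearest neighbour is compound 1, with a 1.7-fold lower number from compound 1 to compound 2 (0.23 log units; within the scatter). Nothing here orders the two compounds, since that step stays within the scatter.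

Compound 3, `Cc1nc(N)sc1CCCN/C(N)=N/C(=O)NCC(C)CC1CCCCC1`, has not been measured. Compared with compound 2 the change is 1-(cyclohexylmethyl)ethyl in place of phenyl on a saturated chain carbon bound to an amide-type nitrogen. Within the data shown here, the only step that bears on this site is the one from compound 1 to compound 2, where a 1.7-fold lower number from compound 1 to compound 2 (0.23 log units; within the scatter). Among the measured compounds shown here, that step shows the site tolerating an exchange between two different groups without a change beyond the scatter, but no measured compound carries a non-aromatic ring at this place, so the basis is thin.

For compound 3 the expectation in this assay is no step beyond the scatter, a 1.2-fold higher number from compound 2 to compound 3 (0.08 log units; within the scatter). The estimate for compound 3 is 120 nM, with a range from 40 nM to 400 nM.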

Compound 3, half-maximal effective concentration: 302 nM
Estimate against measurement, compound 3: 2.5-fold (0.40 log units) below; low and high end bracket the measured number.
By their numbers in this assay, from the lowest: compounds 2, 1 and 3 (each within the scatter of the next, the first and the last beyond it).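

In this assay, among these compounds, 1-(cyclohexylmethyl)ethyl in place of phenyl on a saturated chain carbon bound to an amide-type nitrogen gives the first modest step beyond the scatter at this position, with a 3.0-fold higher number from compound 2 to compound 3 (0.48 log units; beyond the scatter) as the result. Cyclohexylmethyl in place of hydrogen on a saturated chain carbon bound to two saturated chain carbons stays within the scatter, with a 1.8-fold higher number from compound 1 to compound 3 (0.25 log units; within the scatter) on that exchange, and the position therefore shows a limited response to a non-aromatic ring on a branched chain. No supporting data bear on the reason for either step.

The step from phenyl changes the ring and the chain together, and the compounds shown leave open which of the two changes accounts for it. Plain cyclohexyl in place of phenyl, or a branched chain ending in phenyl, would separate them.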